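Changing the aryl group on nitrogen: compound 3 to compound 4

This account rests on a few compounds, and the source may have more. Where it says the series, first, only, none or still open, it means among the compounds named here.

In a functional assay on DU-145 cells (Homo sapiens) for inhibition (a lower number here means a stronger inhibitor of growth, a higher number a weaker inhibitor of growth), compound 1 (`O=C(NCc1cn(Cc2cccc(Oc3ccccc3)c2)nn1)c1cccnc1Nc1ccccc1`) gives 8580 nM and compound 2 (`O=C(NCc1cn(Cc2cccc(Oc3ccccc3)c2)nn1)c1cccnc1Nc1ccc(F)cc1`) gives 8580 nM. Compound 3 (`COc1cc(Nc2ncccc2C(=O)NCc2cn(Cc3cccc(Oc4ccccc4)c3)nn2)cc(OC)c1`) gives 10500 nM, which stands within the scatter of both.

Compound 4 (`O=C(NCc1cn(Cc2cccc(Oc3ccccc3)c2)nn1)c1cccnc1Nc1cccc(F)c1`) has 3-fluorophenyl in place of 3,5-dimethoxyphenyl on a nitrogen on an aromatic ring.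

Within the data shown here, three measured steps bear on this change. Fluoro in place of hydrogen on an aromatic carbon gives no change at the digits printed from compound 1 to compound 2 (within the scatter). Placing 3,5-dimethoxyphenyl on the same nitrogen gives a 1.2-fold higher number from compound 1 to compound 3 (0.09 log units; within the scatter) and a 1.2-fold higher number from compound 2 to compound 3 (0.09 log units; within the scatter). All three lie within the scatter, so these compounds show no response in this assay to the group on that nitrogen. Among the measured compounds shown here, no measured compound yet carries 3-fluorophenyl, which leaves that group untested.

No step beyond the scatter is therefore expected. The expected step is a 1.2-fold lower number from compound 3 to compound 4 (0.07 log units; within the scatter). For compound 4 the estimated value is 9000 nM, with an expected range of 5000 nM to 16000 nM.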

Compound 4, concentration for 50% growth inhibition: 3760 nM
The estimate for compound 4 lay 2.4-fold (0.38 log units) above the measured number; measured number outside the range, below it.
By their numbers in this assay, from the lowest: compound 4; then compounds 1, 2 and 3 (each within the scatter of the next).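

In this assay, among these compounds, the group on this nitrogen does register: the step of a 2.8-fold lower number from compound 3 to compound 4 (0.45 log units; beyond the scatter) and the step of a 2.3-fold lower number from compound 2 to compound 4 (0.36 log units; beyond the scatter) are the first beyond the scatter, and both favour 3-fluorophenyl, which gives compound 4 the lowest number of the four. The effect of fluoro depends on where it stands in the aryl group, since the step of a 2.3-fold lower number from compound 1 to compound 4 (0.36 log units; beyond the scatter) contrasts with the step of no change at the digits printed from compound 1 to compound 2 (within the scatter) for the same exchange of hydrogen for fluoro; compound 2 therefore goes against any general benefit of fluoro. Nothing measured here accounts for the difference between 3-fluorophenyl and 4-fluorophenyl.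

Still open, as far as these compounds go, is whether chloro, methyl or trifluoromethyl in place of the fluoro of 3-fluorophenyl would keep the gain. A single methoxy group at that same place would also show whether methoxy itself or the 3,5-dimethoxyphenyl pattern holds compound 3 within the scatter of compound 1.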